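A few compounds are considered here, and "the series" means these few. Any claim that something is new, unique, unknown or untested is made for them only; others in the source may bear on it.

Measured compounds, with their values in a functional assay on CHO cells for antagonist activity at prostaglandin E2 receptor EP4 subtype (Homo sapiens), read by calcium flux, with a stated time of 15 min; a lower number here means a stronger inhibitor, a higher number a weaker inhibitor:

compound 1 `COc1ccc(Cn2nnc(-c3ccccc3)c2C(=O)N[C@@H](C)c2ccc(C(=O)O)cc2)cc1OC` — 119 nM
compound 2 `C[C@H](NC(=O)c1c(-c2ccccc2)nnn1CCOc1ccc(F)cc1)c1ccc(C(=O)O)cc1` — 3.1 nM
compound 3 `C[C@H](NC(=O)c1c(-c2ccccc2)nnn1CCOc1ccc(C(F)(F)F)cc1)c1ccc(C(=O)O)cc1` — 49.1 nM

Within these three, compound 3 gives the second highest number: it sits nearest compound 1, at a 2.4-fold lower number from compound 1 to compound 3 (0.38 log units; beyond the scatter) read in the reverse direction, and furthest from compound 2, at a 16-fold higher number from compound 2 to compound 3 (1.20 log units; beyond the scatter).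

Compound 4 `C[C@H](NC(=O)c1c(-c2ccccc2)nnn1CC1CCCCC1)c1ccc(C(=O)O)cc1` differs from compound 3 in one place: cyclohexyl in place of (4-(trifluoromethyl)phenoxy)methyl on a saturated chain carbon bound to an aromatic nitrogen. Among the measured compounds shown here, the steps that bear on this position are a 38-fold lower number from compound 1 to compound 2 (1.58 log units; beyond the scatter) and a 2.4-fold lower number from compound 1 to compound 3 (0.38 log units; beyond the scatter), both changes of the group on the same saturated chain carbon; the first was large, the second modest. For the measured compounds named here, neither of them removes the aromatic ring and the ether oxygen altogether, so no measured pair speaks directly to a cyclohexyl there. The position clearly tolerates wide variation, and the two measured replacements both lowered the number from compound 1; on that ground a modest lowering is expected for compound 4, with wide uncertainty in either direction. The estimate for compound 4 in this assay is 35 nM, expected to fall between 7 nM and 180 nM. This expected step from compound 3 to compound 4 is a 1.4-fold lower number from compound 3 to compound 4 (0.15 log units; within the scatter).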

Compound 4, half-maximal inhibitory concentration: > 10000 nM
Compound 4: only a limit was reported; the forecaster's own chance of this, stated with the estimate: 5%; at least 280-fold (2.45 log units) between middle value and limit.
By their numbers in this assay, from the lowest: compound 2; then compound 3; then compound 1. At a limit, above all of these: compound 4.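

In this assay compound 4 gives only a limit, not a number: the limit of > 10000 nM in this assay, at which 1 of the 4 values shown sits.

The earlier changes on the saturated chain carbon bound to an aromatic nitrogen all left a measurable value, whereas cyclohexyl gives an at least 200-fold higher number from compound 3 to compound 4 (2.30 log units; beyond the scatter), an at least 3200-fold higher number from compound 2 to compound 4 (3.50 log units; beyond the scatter) and an at least 84-fold higher number from compound 1 to compound 4 (1.92 log units; beyond the scatter), each a large step. The variation allowed at this position therefore has a limit: the three compounds with numbers all carry an aromatic ring on this carbon, and compound 4 alone carries a non-aromatic ring.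

The compounds shown leave open whether the loss follows the non-aromatic ring itself or some other difference in the group, since a plain phenyl on the same carbon would be the direct partner of compound 4. They also leave open how a piperidine or a pyridine ring would read there.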